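From Compound 2 to Compound 4 in Gastric Cancer Cells

The source may hold more compounds than are shown below. What is called first, only, known or untested is meant among the compounds shown, and "the series" means these compounds.

Of the compounds shown here, three sharing one core have been measured in a functional assay on MGC-803 cells (Homo sapiens) for antiproliferative activity, read by MTT assay, with a stated time of 72 h; a lower number here means a stronger inhibitor, a higher number a weaker inhibitor. Compound 1 `O=C(NO)c1ccc(NCc2nc(-c3cccs3)nn2-c2ccc(O)cc2)cc1` reaches only the limit of the assay, > 20000 nM, and no number. Compound 3 `O=C(NO)c1ccc(NCc2nc(-c3ccccc3Cl)nn2-c2ccccc2)cc1` likewise gives only the limit > 20000 nM. Among the compounds with values here, compound 2 `Cc1cccc(-n2nc(-c3ccccc3)nc2CNc2ccc(C(=O)NO)cc2)c1` is the single member with a measured number, 13200 nM, and so it stands as the one true point on the scale. The two remaining values rest at the limit of > 20000 nM in this assay, at which 2 of the 3 values shown sit. Within the data shown here, no pair of measured compounds differs in just one place, so no step between them can be counted.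

Compound 4 `O=C(NO)c1ccc(NCc2nc(-c3ccccc3)nn2-c2ccc(Br)cc2)cc1` has not yet been measured. It differs from compound 2 by 4-bromophenyl in place of 3-methylphenyl on an aromatic nitrogen. Among the measured compounds shown here, the measured compounds offer no comparable step, so its size cannot be read from them; a change of no more than the scatter, in either direction, is expected, with a real chance that only a limit is reported. Compound 4 is expected to give 15000 nM, within 6000 nM to 40000 nM. This amounts to an expected step of a 1.1-fold higher number from compound 2 to compound 4 (0.06 log units; within the scatter).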

Compound 4, half-maximal inhibitory concentration: 9300 nM
Estimate against measurement, compound 4: 1.6-fold (0.21 log units) above; measured number inside the range.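

In this assay, the exchange of 3-methylphenyl for 4-bromophenyl on an aromatic nitrogen gives a 1.4-fold lower number from compound 2 to compound 4 (0.15 log units; within the scatter). Within the data shown here, this is the first step that can be read, and it shows that these two groups at this position cannot be told apart in this read-out. Compound 4 also adds a second true number to the scale, while the other values offer no step to compare: the limit of > 20000 nM in this assay, at which 2 of the 4 values shown sit.

Because the exchange alters both the substituent and its place on the phenyl ring, the compounds shown cannot separate the contribution of either: the limit of > 20000 nM in this assay, at which 2 of the 4 values shown sit. It also remains open whether an amine or a carboxylic acid on this phenyl ring would move the number beyond the scatter.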